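Dichloropurine benzyl series: removing the chloro between ring nitrogens

This account rests on a few compounds, and the source may have more. Where it says the series, first, only, none or still open, it means among the compounds named here.

Two compounds of this set have numbers in a functional assay on RPMI-8226 cells (Homo sapiens) for cytotoxicity, read by sulforhodamine B assay, with a stated time of 48 h; on this read-out lower numbers stand for stronger inhibition of growth and higher numbers for weaker inhibition of growth. Compound 1 `ClCc1cccc(Cn2cnc3ncnc(Cl)c32)c1` gives 13800 nM in this assay. Compound 2 `ClCc1ccc(Cn2cnc3nc(Cl)nc(Cl)c32)cc1` gives 1650 nM, the lowest of the two numbers; compound 1 stands beyond the scatter from it, but these two compounds differ in more than one place, so their gap cannot be tied to a single change.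

Compound 3 `ClCc1ccc(Cn2cnc3ncnc(Cl)c32)cc1` has not yet been measured in this assay. It differs from compound 2 in one place: hydrogen in place of chloro on an aromatic carbon. For the measured compounds named here, no measured pair in the set isolates this change, so its size can only be guessed. Since compound 1, which carries hydrogen at this position among other differences, sits at 13800 nM, a loss of growth inhibition on removing the chloro is expected, of moderate size and beyond the scatter. The step from compound 2 to compound 3 is estimated at a 3.0-fold higher number from compound 2 to compound 3 (0.48 log units; beyond the scatter). For compound 3 the expected value in this assay is 5000 nM, with a range from 1500 nM to 16000 nM.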

Compound 3, concentration for 50% growth inhibition: 1280 nM
For compound 3 the middle estimate is 3.9-fold (0.59 log units) above the measured one; measured number below the stated range.
By their numbers in this assay, from the lowest: compounds 3 and 2 (each within the scatter of the next); then compound 1.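

In this assay the exchange of chloro for hydrogen on the aromatic carbon between two ring nitrogen atoms comes out as a 1.3-fold lower number from compound 2 to compound 3 (0.11 log units; within the scatter), so growth inhibition at the level of compound 2 does not depend on this chloro. Compound 1 carries the same hydrogen at this position, yet compound 1 gives 13800 nM in this assay, while compound 3 gives 1280 nM in the same read-out. Hydrogen at this position therefore does not by itself go with weak growth inhibition, and the gap between these two values points to the one other place where compound 1 and compound 3 differ, the position of the chloromethyl group on the benzyl ring, though no step for that pair is available here.

Only chloro and hydrogen are shown at this position, so it remains open whether an amine, a methoxy group or a longer chain there would keep the number in the same range. Nothing available explains why the exchange leaves the number within the scatter.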